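The source may report more compounds than this note shows. Statements on the series, on what has been measured and on what is new or still open speak of the compounds shown alone.

The measured compounds:
Compound 1, `COc1ccc(N/C(CCNC2=CC(=O)c3ccccc3C2=O)=N\S(=O)(=O)c2ccc(C)cc2)cc1`, giving 35100 nM in an ADME assay on HEK293 cells (Homo sapiens) for cytotoxicity, read by MTT assay, with a stated time of 48 h; a higher number here means a weaker inhibitor, a lower number a stronger inhibitor.
Compound 2, `Cc1ccc(S(=O)(=O)/N=C(/CCNC2=CC(=O)c3ccccc3C2=O)Nc2cccc(C(F)(F)F)c2)cc1`, giving 91500 nM.
Compound 3, `COc1cc(N/C(CCNC2=CC(=O)c3ccccc3C2=O)=N\S(=O)(=O)c2ccc(C)cc2)cc(OC)c1OC`, giving 75800 nM.

Compound 2 carries the highest of the three numbers. Its distance from compound 1 is a 2.6-fold higher number from compound 1 to compound 2 (0.42 log units; beyond the scatter), a step beyond the scatter, whereas its distance from compound 3 is only a 1.2-fold lower number from compound 2 to compound 3 (0.08 log units; within the scatter), which lies within the scatter. The change from compound 1 to compound 3 was a 2.2-fold higher number from compound 1 to compound 3 (0.33 log units; beyond the scatter).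

The new compound is compound 4, `Cc1ccc(S(=O)(=O)/N=C(/CCNC2=CC(=O)c3ccccc3C2=O)NCc2ccccc2)cc1`. It differs from compound 2 by benzyl in place of 3-(trifluoromethyl)phenyl on an amine nitrogen. For the measured compounds named here, no measured step replaces an aryl group on this nitrogen by a benzyl group, so the bearing of the known steps is indirect. The two steps that did alter the aryl group on this nitrogen, from compound 1 to compound 2 and from compound 1 to compound 3, were both modest, and the step from compound 2 to compound 3 stayed within the scatter. A modest step in this assay is therefore expected, with no firm direction, leaning slightly toward a lower number. For compound 4 the estimate is 60000 nM, between 25000 nM and 150000 nM, which means an expected step of a 1.5-fold lower number from compound 2 to compound 4 (0.18 log units; within the scatter).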

Compound 4, half-maximal inhibitory concentration: 80200 nM
Beside the measured number, compound 4's estimate is 1.3-fold (0.13 log units) below it; the range from low to high includes it.
By their numbers in this assay, from the lowest: compound 1; then compounds 3, 4 and 2 (each within the scatter of the next).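

In this assay, the change from an aryl group to benzyl on this amine nitrogen gives a 1.1-fold lower number from compound 2 to compound 4 (0.06 log units; within the scatter) and a 1.1-fold higher number from compound 3 to compound 4 (0.02 log units; within the scatter), so among these compounds benzyl cannot be told apart from 3-(trifluoromethyl)phenyl or 3,4,5-trimethoxyphenyl, and the ring need not be an aryl group on the nitrogen itself for the number to stay in this range. For the compounds shown here, compound 1 remains the one that stands apart, with a 2.3-fold higher number from compound 1 to compound 4 (0.36 log units; beyond the scatter), which makes 4-methoxyphenyl the only group of the four whose steps to all the others lie beyond the scatter. Nothing available explains these steps or the separate position of compound 1.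

The compounds shown leave open whether 4-methoxybenzyl on this nitrogen would bring the number back toward that of compound 1, or whether that low number belongs to 4-methoxyphenyl alone, given that compound 3 also carries methoxy groups and does not share it. They also leave open how a longer chain such as phenethyl, or a saturated ring such as cyclohexyl, would behave at this position.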